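Swapping isobutyl for a methylpyrazole on the amide nitrogen

The compounds below may be only part of what the source reports. "The series", "measured", "known", "first", "only" and "open" are said of these compounds alone.

Compound 1: `Cc1ccc(OCC(=O)N(Cc2cccs2)CC(C)C)cc1` — 900 nM
Compound 2: `CCN(Cc1cc[nH]c1)C(=O)COc1ccc(C)cc1` — 21800 nM
Compound 3: `CCN(Cc1cccs1)C(=O)COc1ccc2c(c1)COC2` — 61 nM

In an assay on HEK293 cells for agonist activity at transient receptor potential cation channel subfamily M member 8 (Homo sapiens), read by fluorescence and calcium flux, with a stated time of 15 min (a lower number here means that less compound is needed, a higher number that more compound is needed for the effect), compound 1 gives 900 nM, which places it second highest among the three measured numbers. Its nearest neighbour is compound 3, whose value in this assay is lower, a gap that lies beyond the scatter of the assay. Its furthest neighbour is compound 2, whose value in this assay is higher, again beyond the scatter. Compound 4, `Cc1ccc(OCC(=O)N(Cc2cccs2)c2cnn(C)c2)cc1`, has not been measured. It differs from compound 1 in one place: 1-methyl-1H-pyrazol-4-yl in place of isobutyl on an amide-type nitrogen. Within the data shown here, no measured pair among the three compounds shows this kind of change, so the size of the step is open. The account expects a moderate step upward in this assay, larger than the scatter but not by much, with the direction itself uncertain. Compound 4 is therefore estimated to give 2500 nM in this assay, within a range from 500 nM to 15000 nM, a step of a 2.8-fold higher number from compound 1 to compound 4 (0.44 log units; beyond the scatter).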

Compound 4, half-maximal effective concentration: 63000 nM
Compound 4: middle estimate off by 25-fold (1.40 log units), on the low side; measured number outside the range, above it.
By their numbers in this assay, from the lowest: compound 3; then compound 1; then compound 2; then compound 4.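

In this assay, putting 1-methyl-1H-pyrazol-4-yl in place of isobutyl on the amide-type nitrogen gives a 70-fold higher number from compound 1 to compound 4 (1.85 log units; beyond the scatter) and is the first one-place change available among these compounds. With the rest of compound 1 held fixed, this single substituent moves the number upward by a large step, so the assay is strongly sensitive to this exchange at this nitrogen. Nothing at hand accounts for the size of the step, which stands as an observation without an explanation.

The compounds shown leave open whether the step follows from the pyrazole ring or from its methyl group, and whether a cyclopentyl, a phenyl or a longer chain on this nitrogen would stay close to compound 1. Going by these compounds, whether the same exchange would produce a similar step on the core of compound 3 also remains open.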